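This account rests on a few compounds, and the source may have more. Where it says the series, first, only, none or still open, it means among the compounds named here.

Compound 1 `CC1(C)[C@@H]2CC[C@@]1(CS(=O)(=O)N1CCN(c3ccc(Br)cn3)CC1)C(=O)C2` gives 1580 nM in a functional assay on CHO-K1 cells for antagonist activity at C-X-C chemokine receptor type 3 (Homo sapiens), read by FLIPR and calcium flux; a lower number here means a stronger inhibitor, a higher number a weaker inhibitor. Compound 2 `CC1(C)[C@@H]2CC[C@@]1(CS(=O)(=O)N1CCN(c3ccc([N+](=O)[O-])cn3)CC1)C(=O)C2` reaches only the limit of the assay, > 31600 nM. Compound 3 `CC(=O)c1ccc(N2CCN(S(=O)(=O)C[C@]34CC[C@H](CC3=O)C4(C)C)CC2)nc1` likewise sits at a limit, > 31600 nM, so it stands at the limit of > 31600 nM in this assay, at which 2 of the 3 values shown sit, rather than at a number. The swaps on the aromatic carbon gave an at least 20-fold higher number from compound 1 to compound 2 (1.30 log units; beyond the scatter) and an at least 20-fold higher number from compound 1 to compound 3 (1.30 log units; beyond the scatter), while a step that the two limits leave unreadable from compound 2 to compound 3. Compound 4 `CC1(C)[C@@H]2CC[C@@]1(CS(=O)(=O)N1CCN(c3ccc(C(F)(F)F)cc3)CC1)C(=O)C2` differs from compound 3 by 4-(trifluoromethyl)phenyl in place of 5-acetylpyridin-2-yl on an amine nitrogen in a ring. Among the measured compounds shown here, no measured step follows this exact exchange, but the two readable steps show that changing the aromatic ring moves the number strongly. Compound 4 is therefore expected to return toward a readable value, with an at least 7.9-fold lower number from compound 3 to compound 4 (0.89 log units; beyond the scatter) as the estimated step, giving an estimate of 4000 nM, between 600 nM and 31600 nM.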

Compound 4, half-maximal inhibitory concentration: > 31600 nM
Compound 4: a limit, no number (the forecaster's own chance of this, stated with the estimate: 35%); middle value at least 7.9-fold (0.89 log units) from the limit.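

Swapping the whole aromatic group for 4-(trifluoromethyl)phenyl, a ring of carbon only, gives an at least 20-fold higher number from compound 1 to compound 4 (1.30 log units; beyond the scatter). So the loss at this position is not confined to the nitro and acetyl groups on the ring that bears a nitrogen, and the 5-bromopyridin-2-yl group of compound 1 remains the only one here with a readable value. The steps among compound 2, compound 3 and compound 4 cannot be read, and the other compounds sit at a limit: the limit of > 31600 nM in this assay, at which 3 of the 4 values shown sit.

From the compounds shown here alone, whether compound 1 owes its readable value to the bromo group or to the nitrogen of its aromatic ring stays open. A 4-bromophenyl or a 5-chloropyridin-2-yl group on the same amine nitrogen would help to separate the two.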